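A few compounds are considered here, and "the series" means these few. Any claim that something is new, unique, unknown or untested is made for them only; others in the source may bear on it.

Measured so far:
- compound 1, `O=C1NCCN1c1ccc(S(=O)(=O)Nc2ccc(C3CCCCC3)cc2)cc1`: > 1000 nM
- compound 2, `CCCCc1ccc(NS(=O)(=O)c2ccc(N3CCNC3=O)cc2)cc1`: 450 nM
- compound 3, `CC(C)(C)c1ccc(NS(=O)(=O)c2ccc(N3CCNC3=O)cc2)cc1`: > 1000 nM

All three share one core and differ only in the group carried on an aromatic carbon of the outer ring. In a functional assay on M21 cells (Homo sapiens) for antiproliferative activity, read by sulforhodamine B assay, with a stated time of 48 h (a higher number here means a weaker inhibitor, a lower number a stronger inhibitor), compound 1 does not reach a number: its value of > 1000 nM is a limit of the assay. Compound 3 also ends at a limit, > 1000 nM. Compound 2 alone gives a number, 450 nM. The measured steps are an at least 2.2-fold lower number from compound 1 to compound 2 (0.34 log units; beyond the scatter), an at least 2.2-fold higher number from compound 2 to compound 3 (0.34 log units; beyond the scatter) and a step that the two limits leave unreadable from compound 1 to compound 3. Because (the limit of > 1000 nM in this assay, at which 2 of the 3 values shown sit), compound 1 cannot be placed exactly; it is known only to be no stronger than the weaker end of what was measured.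

Compound 4, `O=C1NCCN1c1ccc(S(=O)(=O)Nc2ccc(Br)cc2)cc1`, differs from compound 1 by bromo in place of cyclohexyl on an aromatic carbon. Within the data shown here, no measured step involves bromo, so the only guidance is indirect: exchanging the cyclohexyl for a butyl chain gave a readable, lower number, while tert-butyl stayed at the limit. Compound 4 is therefore expected to land near the limit, with about an even chance of a number. Compound 4 is estimated at 900 nM, in a range from 300 nM to 3000 nM. That estimate corresponds to an expected step of an at least 1.1-fold lower number from compound 1 to compound 4 (0.04 log units; that floor lies within the scatter).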

Compound 4, half-maximal inhibitory concentration: 130 nM
Estimate against measurement, compound 4: 6.9-fold (0.84 log units) above; measured number below the stated range.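

In this assay, this position gives its best result so far with a single bromine atom rather than a carbon group: the change shows an at least 7.6-fold lower number from compound 1 to compound 4 (0.88 log units; beyond the scatter), and replacing tert-butyl shows an at least 7.6-fold lower number from compound 3 to compound 4 (0.88 log units; beyond the scatter). These two steps give only a minimum size, because neither compound 1 nor compound 3 has an exact number: the limit of > 1000 nM in this assay, at which 2 of the 4 values shown sit. Bromo also improves on butyl, the only carbon group here with a readable value, with a 3.5-fold lower number from compound 2 to compound 4 (0.54 log units; beyond the scatter), which makes compound 4 the strongest of the four compounds and shows that a carbon chain or ring is not needed at this position for activity.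

Going by these compounds, four groups cannot show which feature of bromo matters, and it remains open whether chloro, iodo, methoxy, an amine or a carboxylic acid at the same carbon would match it. The comparison also covers only this one assay of cell growth, so it leaves open how compound 4 would behave on other cell lines or over a different exposure time.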